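The source may report more compounds than this note shows. Statements on the series, on what has been measured and on what is new or still open speak of the compounds shown alone.

Measured compounds:
- compound 1, `O=C(Cn1c(=O)oc2cc(Cl)ccc21)NCc1cccs1`: 53.6%
- compound 2, `O=C(Cn1c(=O)oc2cc(Cl)ccc21)Nc1nc2ccccc2s1`: 52.5%
- compound 3, `O=C(Cn1c(=O)oc2ccccc21)NCc1cccs1`: 49.1%

All three were tested in an ADME assay on RAW264.7 cells (Mus musculus) for cytotoxicity, read by MTT assay, with a stated time of 72 h, tested at 100 uM; on this read-out higher numbers stand for a stronger effect at the one concentration tested and lower numbers for a weaker effect. On these numbers compound 1 holds the highest value of the three, but its gap to compound 2 and its gap to compound 3 both lie within the usual scatter, so the three compounds are not separated from one another. Going by the values given here, the one step measured between two compounds differing in a single place is a number 4.5 percentage points lower from compound 1 to compound 3 (within the scatter), and it changed nothing beyond the scatter.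

The next compound, compound 4, is `O=C(Cn1c(=O)oc2cc(Cl)ccc21)NCc1ccco1`. It differs from compound 1 in this way: furan-2-yl in place of thiophen-2-yl on a saturated chain carbon bound to an amide-type nitrogen

Among the compounds with values here, no measured step involves this exchange of one five-membered ring for another on the amide side of the molecule; the only step known, from compound 1 to compound 3, concerns a different part of the shared core and was small. With nothing pointing either way, the expectation for a number 3.6 percentage points lower from compound 1 to compound 4 (within the scatter) is a step that stays within the scatter. Compound 4 is therefore estimated at 50%, with a range from 36% to 63%.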

Compound 4, a percentage reported as inhibition, at one concentration (the size of the read-out at that concentration, not a potency): 50.3%
Beside the measured number, compound 4's estimate is 0.3 percentage points below it, within the range that was stated.
By their numbers in this assay, from the lowest: compounds 3, 4, 2 and 1 (each within the scatter of the next).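

Going by these compounds alone, exchanging thiophen-2-yl for furan-2-yl on a saturated chain carbon bound to an amide-type nitrogen gives a number 3.3 percentage points lower from compound 1 to compound 4 (within the scatter) in this assay, the first measured change at this position, and it moves nothing beyond the scatter. With the core of compound 1 kept, sulfur and oxygen as the one hetero atom of this five-membered aromatic ring are therefore not told apart by this read-out at the one concentration tested. Nothing measured offers a reason for the size of this step.

As far as these compounds go, it remains open whether a different group at this place, such as a phenyl ring, an amine or a carboxylic acid, would move the number beyond the scatter. Also open, from the compounds shown here alone, is whether furan-2-yl gives the same picture on the core without chloro, as carried by compound 3.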